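Replacing a Thienyl Ketone with a Fluorosulfonyloxy Group

The source may hold more compounds than are shown below. What is called first, only, known or untested is meant among the compounds shown, and "the series" means these compounds.

Compound 1 `CC1(C)C=C(n2ccccc2=O)c2cc(C(=O)c3cccs3)ccc2O1` gives 6.4 in a functional assay (aorta) with Rattus norvegicus as the target (a higher number here means a more potent compound, by a factor of ten per unit of this negative logarithm, a lower number a less potent compound), the highest of the three numbers available. Compound 2 `CC1(C)C=C(n2ccccc2=O)c2cc(C(=O)c3ccc([N+](=O)[O-])cc3)ccc2O1` gives 6.2 in this assay, and the step of a number 0.20 log units lower from compound 1 to compound 2 (within the scatter) shows that changing the aryl ring on the carbonyl makes little difference. Compound 3 `CC1(C)C=C(n2ccccc2=O)c2cc(OC(=O)Nc3ccc(C(F)(F)F)cc3)ccc2O1` gives 5.1, well below compound 1. Compound 4 `CC1(C)C=C(n2ccccc2=O)c2cc(OS(=O)(=O)F)ccc2O1` carries (fluorosulfonyl)oxy in place of (thiophen-2-yl)carbonyl on an aromatic carbon, removing the carbonyl and its ring entirely. Among the measured compounds shown here, no measured step covers this change directly; the only step available, that from compound 1 to compound 2, concerns a swap of aryl groups, while compound 3, which also carries an oxygen-linked group on that carbon, sits far lower. A loss in this assay is therefore expected, with the step of a number 1.00 log units lower from compound 1 to compound 4 (beyond the scatter). Compound 4 is estimated at 5.4, between 4.6 and 6.2.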

Compound 4, logarithm of the reciprocal of the active concentration, log(1/C): 7.95
For compound 4 the middle estimate is 2.55 log units below the measured one; measured number above the stated range.
By their numbers in this assay, from the lowest: compound 3; then compounds 2 and 1 (each within the scatter of the next); then compound 4.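

Putting (fluorosulfonyl)oxy in place of (thiophen-2-yl)carbonyl on this aromatic carbon gives a number 1.55 log units higher from compound 1 to compound 4 (beyond the scatter) in this assay, so neither the carbonyl nor its ring is needed here. An oxygen link at this carbon does not by itself set the number, as compound 3 gives 5.1 and compound 4 gives 7.95. Nothing available accounts for this gain.

What the compounds shown leave open is whether a methanesulfonyloxy group or a plain hydroxyl on this carbon would keep the number of compound 4, and so whether the fluorine or the sulfonyl part carries the step.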